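One More Ring Nitrogen on the Saturated Carbon

The compounds below may be only part of what the source reports. "The series", "measured", "known", "first", "only" and "open" are said of these compounds alone.

Among the compounds with values here, compound 2 `Cc1nc(N2CCC(N3CCCC3=O)CC2)nc2ccc(NC(=O)/C=C/c3ccc(OC(F)(F)F)cc3)cc12` gives the lowest of the two numbers so far in an assay on CHO-K1 cells for displacement of a labelled ligand from melanin-concentrating hormone receptor 1 (Homo sapiens), read by scintillation proximity assay, with a stated time of 2 h (on this read-out higher numbers stand for weaker inhibition and lower numbers for stronger inhibition), at 11 nM. Compound 1 `Cc1nc(N2CCC(NS(=O)(=O)N(C)C)CC2)nc2ccc(NC(=O)/C=C/c3ccc(OC(F)(F)F)cc3)cc12` stands nearest, giving 105 nM in this assay, and the step of a 9.5-fold lower number from compound 1 to compound 2 (0.98 log units; beyond the scatter) is the only one measured. Compound 3 `Cc1nc(N2CCC(N3CCN(C)C3=O)CC2)nc2ccc(NC(=O)/C=C/c3ccc(OC(F)(F)F)cc3)cc12` differs from compound 2 in that (3-methyl-2-oxoimidazolidin-1-yl in place of 2-oxopyrrolidin-1-yl on a saturated ring carbon). That earlier step concerned a different exchange and bears only loosely here, since the five-membered ring on the saturated ring carbon is kept. The step of a 1.4-fold higher number from compound 2 to compound 3 (0.13 log units; within the scatter) is therefore expected to stay within the scatter. Compound 3 is estimated at 15 nM in this assay, within 5 nM to 45 nM.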

Compound 3, half-maximal inhibitory concentration: 21 nM
For compound 3 the middle estimate is 1.4-fold (0.15 log units) below the measured one, and the stated range covers the measured number.
By their numbers in this assay, from the lowest: compounds 2 and 3 (each within the scatter of the next); then compound 1.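

In this assay, the 3-methyl-2-oxoimidazolidin-1-yl group on the saturated ring carbon reads the same within the scatter as 2-oxopyrrolidin-1-yl (a 1.9-fold higher number from compound 2 to compound 3 (0.28 log units; within the scatter)). It also stays clear of (dimethylsulfamoyl)amino (a 5.0-fold lower number from compound 1 to compound 3 (0.70 log units; beyond the scatter)), so the advantage seen earlier extends to a second five-membered non-aromatic ring with a carbonyl. No evidence is available to explain either step. The compounds shown leave open whether the ring carbonyl is needed, as a plain pyrrolidin-1-yl amine would test, and whether a six-membered 2-oxopiperidin-1-yl ring would serve equally well.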